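The source may hold more compounds than are shown below. What is called first, only, known or untested is meant among the compounds shown, and "the series" means these compounds.

Compound 1 `O=C(N/N=C/c1cc(I)cc(I)c1O)c1ccc(Cl)cc1`: 14800 nM
Compound 2 `CC(C)(C)c1ccc(C(=O)N/N=C/c2cc(I)c(O)c(I)c2)cc1`: 45900 nM

In a functional assay on HepG2 cells (Homo sapiens) for cytotoxicity, with a stated time of 24 h (a higher number here means a weaker inhibitor, a lower number a stronger inhibitor), compound 2 gives the higher of these two numbers; compound 1 sits lower, and that gap is beyond the usual scatter. Compound 3 `O=C(N/N=C/c1cc(I)c(O)c(I)c1)c1ccc([N+](=O)[O-])cc1` has not been measured. It differs from compound 2 by nitro in place of tert-butyl on an aromatic carbon, para to a large group. For the measured compounds named here, no measured pair shows this exchange, so its effect is unknown; the step expected from it, a 1.6-fold lower number from compound 2 to compound 3 (0.21 log units; within the scatter), is a move toward a lower number, perhaps no larger than the scatter. Compound 3 is estimated at 28000 nM, between 9000 nM and 90000 nM.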

Compound 3, half-maximal inhibitory concentration: 92100 nM
Compound 3: middle estimate off by 3.3-fold (0.52 log units), on the low side, and the stated range ends below it.
By their numbers in this assay, from the lowest: compound 1; then compounds 2 and 3 (each within the scatter of the next).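

In this assay, nitro in place of tert-butyl on an aromatic carbon, para to a large group, gives a 2.0-fold higher number from compound 2 to compound 3 (0.30 log units; within the scatter), so this exchange does not separate the two compounds beyond the usual scatter. The two groups differ in their atoms and hydrogen-bond acceptors, yet this single pair shows no clear shift in the read-out. Nothing measured here offers an explanation for this result.

On these data alone, whether an amine or a carboxylic acid at this position would also stay within the scatter remains open. Compound 1 differs from both compounds in more than one place, so it gives no reading of this exchange.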